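Permeability notes on a substituted amine series

A few compounds are considered here, and "the series" means these few. Any claim that something is new, unique, unknown or untested is made for them only; others in the source may bear on it.

Compound 2 `CNC1=NCCC2(CCCCC2)S1` carries a methylamino group on the shared core; in a physicochemical assay for permeability (on this read-out lower numbers stand for lower permeability and higher numbers for higher permeability), compound 2 gives 2.7 10^-6 cm/s. Compound 1 `CCNC1=NCCC2(CCCCC2)S1` differs from it by methyl in place of hydrogen on a saturated chain carbon bound to an amine nitrogen and in this assay compound 1 gives 8.78 10^-6 cm/s, a step of a 3.3-fold higher number from compound 2 to compound 1 (0.51 log units; beyond the scatter). Compound 3 `CCc1ccc(NC2=NCCC3(CCCCC3)S2)cc1` bears an arylamino group on the same core; the difference between the cores of compound 3 and compound 2 is not broken down here. In this assay compound 3 gives 41 10^-6 cm/s, the highest of the three numbers.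

Compound 4 `CC(C)c1ccc(NC2=NCCC3(CCCCC3)S2)cc1` is the unmeasured analogue of compound 3, with methyl in place of hydrogen on a saturated chain carbon bound to an aromatic carbon and a saturated chain carbon. Among the measured compounds shown here, this is the same kind of change as the one from compound 2 to compound 1, but not the same: there the place was a saturated chain carbon bound to an amine nitrogen, here it is a saturated chain carbon bound to an aromatic carbon and a saturated chain carbon. A smaller step is expected here, a 1.3-fold higher number from compound 3 to compound 4 (0.13 log units; within the scatter), since compound 3 already starts high at 41 10^-6 cm/s. Compound 4 is expected to give about 55 10^-6 cm/s, between 30 10^-6 cm/s and 90 10^-6 cm/s.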

Compound 4, apparent permeability: 15.7 10^-6 cm/s
The estimate for compound 4 lay 3.5-fold (0.54 log units) above the measured number; the measured number lies below the stated range.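

In this assay, methyl in place of hydrogen on a saturated chain carbon bound to an aromatic carbon and a saturated chain carbon gives a 2.6-fold lower number from compound 3 to compound 4 (0.42 log units; beyond the scatter), whereas the same kind of change on a saturated chain carbon bound to an amine nitrogen gives a 3.3-fold higher number from compound 2 to compound 1 (0.51 log units; beyond the scatter), so the two steps, both beyond the scatter, run in opposite directions. This shows that the direction of the first step does not carry over to the second, but the core and the place differ together across these two steps, so neither can be singled out as going with the reversal, and two steps alone set no rule for the series. No measurement shown bears on the reason for the reversal.

From the compounds shown here alone, an isopropyl group on the amine nitrogen of the core of compound 1 would put the ethyl to isopropyl change at the place of the earlier step, and that result remains open. Also open, going by these compounds, is whether a tert-butyl group or a longer chain such as propyl, on the aromatic ring of compound 3, would follow compound 4 or depart from it.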